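An aryl ester in place of a benzyl carbamate

The source may report more compounds than this note shows. Statements on the series, on what has been measured and on what is new or still open speak of the compounds shown alone.

In a functional assay on MCF7 cells (Homo sapiens) for antiproliferative activity, read by MTT assay, with a stated time of 72 h (a lower number here means a stronger inhibitor, a higher number a weaker inhibitor), compound 3 `CC1=CC[C@H]2[C@H](CC[C@]2(C)O)C(C)(C)[C@@H]1CC[C@H]1[C@]2(C)CC[C@H](OC(=O)NCc3ccccc3)C(C)(C)O[C@H]2CC[C@@]1(C)O` gives 24500 nM, the lowest of the two numbers shown. Its nearest neighbour is compound 1 `CC(=O)O[C@H]1CC[C@]2(C)[C@H](CC[C@@](C)(O)[C@H]2CC[C@@H]2C(C)=CC[C@@H]3C(C)=CC[C@@H]3C2(C)C)OC1(C)C`, which in this assay gives 43500 nM, a gap that lies within the scatter. Compound 2 `CC1=CC[C@H]2[C@@H]1CC=C(C)[C@@H](CC[C@H]1[C@]3(C)CC[C@H](OC(=O)c4ccc(C)cc4)C(C)(C)O[C@H]3CC[C@@]1(C)O)C2(C)C` in this assay reaches only a limit, > 50000 nM (the limit of > 50000 nM in this assay, at which 1 of the 3 values shown sits).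

Compound 4 `CC1=CC[C@H]2[C@H](CC[C@]2(C)O)C(C)(C)[C@@H]1CC[C@H]1[C@]2(C)CC[C@H](OC(=O)c3ccc(C(F)(F)F)cc3F)C(C)(C)O[C@H]2CC[C@@]1(C)O` differs from compound 3 in one place: 2-fluoro-4-(trifluoromethyl)phenyl in place of benzylamino on a carbonyl carbon.

Among the compounds with values here, the only measured step that touches the same carbonyl carbon is an at least 1.1-fold higher number from compound 1 to compound 2 (0.06 log units; that floor lies within the scatter), where an aromatic ring entered in place of methyl and the number rose at least to the limit. That step sits on the shared core of compounds 1 and 2, not on that of compound 3, and it concerns an ester on both sides, whereas here a carbamate gives way to an ester. Within the data shown here, no step beyond the scatter is therefore expected, though the direction of the one measured step points toward a higher number. Compound 4 is expected to give about 40000 nM, between 18000 nM and 90000 nM. That estimate means a step of a 1.6-fold higher number from compound 3 to compound 4 (0.21 log units; within the scatter).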

Compound 4, half-maximal inhibitory concentration: > 50000 nM
Compound 4: a limit, no number; the forecaster's own chance of this, stated with the estimate: 35%; middle value at least 1.2-fold (0.09 log units) away from the limit.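

Replacing benzylamino with 2-fluoro-4-(trifluoromethyl)phenyl on this carbonyl carbon gives an at least 2.0-fold higher number from compound 3 to compound 4 (0.30 log units; that floor lies within the scatter), the first step shown that replaces a carbamate with an ester at this position. As far as these compounds go, only a floor can be read, so the size of the step remains unknown, and the change gives no sign of a lower number than that of compound 3. In this assay the result for compound 4 is a limit, and an aromatic ester now stands at that limit on two cores, in compound 2 and compound 4: the limit of > 50000 nM in this assay, at which 2 of the 4 values shown sit.

The compounds shown cannot separate the loss of the benzylamino nitrogen from the entry of the fluorine-bearing ring. From the compounds shown here alone, it remains open how an unsubstituted phenyl or a methylamino group on this carbonyl carbon would behave on the core of compound 3.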